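This account rests on a few compounds, and the source may have more. Where it says the series, first, only, none or still open, it means among the compounds named here.

Compound 1, `O=C(Nc1ccc(C(F)(F)F)cc1)c1ccc(Cl)cc1O`, gives 580 nM in a functional assay on KG-1 cells (Homo sapiens) for cytotoxicity, read by luminescence and CellTiter-Glo, with a stated time of 3 days; a higher number here means a weaker inhibitor, a lower number a stronger inhibitor.
Compound 2, `O=C(Nc1ccc(C(F)(F)F)cc1)c1ccc(Br)cc1O`, gives 340 nM in this assay.
Compound 3, `O=C(Nc1ccc(Cl)c(Cl)c1)c1cc(F)ccc1O`, gives 760 nM in this assay.

Compounds 1 and 2 share one core and differ in a single place: bromo in place of chloro on an aromatic carbon. That change gave a 1.7-fold lower number from compound 1 to compound 2 (0.23 log units; within the scatter), so the two numbers cannot be told apart with confidence. Compound 3 is built on a different core; the difference between the two cores is not broken down here. Compound 4, `O=C(Nc1ccc(Br)c(Cl)c1)c1cc(F)ccc1O`, has not yet been measured. It differs from compound 3 in one place: bromo in place of chloro on an aromatic carbon. Among the compounds with values here, this is the same kind of change as the one from compound 1 to compound 2, but the surroundings are not identical: in the earlier pair the position is meta to a hydroxy group, while in compound 3 it is ortho to a chloro group; in both it is para to a large group. Because the earlier step was a 1.7-fold lower number from compound 1 to compound 2 (0.23 log units; within the scatter), the expected step is a 1.6-fold lower number from compound 3 to compound 4 (0.21 log units; within the scatter), a small shift at most. Compound 4 is therefore estimated at 470 nM in this assay, with a range from 230 nM to 950 nM.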

Compound 4, half-maximal inhibitory concentration: 670 nM
The estimate for compound 4 lay 1.4-fold (0.15 log units) below the measured number; measured number inside the range.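

Replacing chloro with bromo gave a 1.1-fold lower number from compound 3 to compound 4 (0.05 log units; within the scatter) in this assay, so on this second core, as on the first, the two compounds cannot be told apart with confidence. Set side by side, the two steps show no detectable difference between the cores: the same change on two cores in this assay, a 1.7-fold lower number (0.23 log units; within the scatter) from compound 1 to compound 2 and a 1.1-fold lower number (0.05 log units; within the scatter) from compound 3 to compound 4, 1.5-fold (0.18 log units) apart, within the scatter of two such steps. This shows that the change has stayed small on both cores, but it does not show that bromo and chloro truly differ on either one, and two pairs say nothing about how the change would behave on any further core.

The compounds shown carry only chloro or bromo at the changed place, so it remains open how an amine, a carboxylic acid or a longer chain there would read in this assay. Also open, from the compounds shown here alone, is what would happen to the number if a methoxy group took the place of the hydroxy group that all four compounds carry.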